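Swapping a Bicyclic Acid for an Aromatic Acid on the Ring Nitrogen

The source may hold more compounds than are shown below. What is called first, only, known or untested is meant among the compounds shown, and "the series" means these compounds.

Measured so far:
Compound 1 `O=C(O)C12CC(CN3CCC[C@H](O[C@H](CO)c4cc(Cl)cc(Cl)c4)[C@@H]3c3ccccc3)(C1)C2`: 12000 nM
Compound 2 `Cc1cc(C(=O)O)ccc1CN1CCC[C@H](O[C@H](CO)c2cc(Cl)cc(Cl)c2)[C@@H]1c1cccc(F)c1`: 12000 nM

Of the compounds shown here, two have been tested in an assay on isolated protein for activation of cGMP-dependent protein kinase 1 (Homo sapiens), read by ADP-Glo, with stated times of 30 min and 2 h, in the presence of a further agent that is not named here; on this read-out lower numbers stand for an effect already at smaller amounts and higher numbers for an effect only at larger amounts of compound. Compound 1 gives 12000 nM, and compound 2 gives 12000 nM. The two numbers are level at the digits shown, and the nearest neighbour of compound 1 on this read-out is compound 2, with no change beyond the scatter between them; no step between measured compounds is computed here, so the pair is read only as two equal values.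

Compound 3 `Cc1cc(C(=O)O)ccc1C(C)N1CCC[C@H](O[C@H](CO)c2cc(Cl)cc(Cl)c2)[C@@H]1c1ccccc1` has not yet been measured. It differs from compound 1 by a group of 12 heavy atoms (10 carbon, 2 oxygen; one six-membered aromatic ring of carbon only) in place of a group of 9 heavy atoms (7 carbon, 2 oxygen; 2 four-membered non-aromatic rings of carbon only), on an amine nitrogen in a ring, in words a group of 12 heavy atoms (10 carbon, 2 oxygen; one six-membered aromatic ring of carbon only) in place of a group of 9 heavy atoms (7 carbon, 2 oxygen; 2 four-membered non-aromatic rings of carbon only), on an amine nitrogen in a ring. Compound 2 already carries an aromatic acid group of this kind and sits level with compound 1. From that, no step beyond the scatter is expected in this assay; the estimated step is a 1.2-fold lower number from compound 1 to compound 3 (0.08 log units; within the scatter). Compound 3 is expected to give 10000 nM, with a range from 3000 nM to 30000 nM.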

Compound 3, half-maximal effective concentration: 18000 nM
The estimate for compound 3 lay 1.8-fold (0.26 log units) below the measured number; low and high end bracket the measured number.
By their numbers in this assay, from the lowest: compounds 1, 2 and 3 (each within the scatter of the next).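

In this assay, among the compounds shown here, this is the first comparison of compounds that differ in one place, and the exchange on the amine nitrogen in a ring gives a 1.5-fold higher number from compound 1 to compound 3 (0.18 log units; within the scatter). For this pair, the group with 2 four-membered non-aromatic rings of carbon only and the larger group with one six-membered aromatic ring of carbon only therefore cannot be told apart on this read-out, and the change at this position, on the ring nitrogen of the shared core, does not by itself carry the number beyond the scatter. Nothing measured alongside these compounds bears on why the two groups read alike.

The compounds shown leave open whether the carboxylic acid that both groups carry matters at all, since no group here replaces it with a primary amide, a tetrazole or a basic amine. They also leave open whether a longer chain linking the acid to the ring nitrogen, or a simple benzyl or methyl group on that nitrogen, would move the number beyond the scatter in either direction.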